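A few compounds are considered here, and "the series" means these few. Any claim that something is new, unique, unknown or untested is made for them only; others in the source may bear on it.

Compound 2 `O=S(=O)(NCCCNCc1ccc(Cl)cc1)c1cc(C(F)(F)F)cc(C(F)(F)F)c1` gives 2900 nM in a functional assay on BE(2)-C cells (Homo sapiens) for inhibition, read by MTT assay, with a stated time of 72 h; on this read-out higher numbers stand for weaker inhibition of growth and lower numbers for stronger inhibition of growth. For the measured compounds named here, that is one of only two numbers measured, the other being compound 1 `O=S(=O)(NCCCNCC1COc2ccccc2O1)c1cc(C(F)(F)F)cc(C(F)(F)F)c1` at 2800 nM, and the two sit within the scatter of each other. Compound 3 `COc1ccccc1CNCCCNS(=O)(=O)c1cc(C(F)(F)F)cc(C(F)(F)F)c1` differs from compound 2 by 2-methoxyphenyl in place of 4-chlorophenyl on a saturated chain carbon bound to an amine nitrogen. Going by the values given here, the single step seen so far, a 1.0-fold higher number from compound 1 to compound 2 (0.02 log units; within the scatter), also swapped the group on that same chain carbon and stayed within the scatter. The step of a 1.0-fold higher number from compound 2 to compound 3 (0.01 log units; within the scatter) is therefore expected to be none beyond the scatter. Compound 3 is estimated at 3000 nM, with a range from 1400 nM to 6500 nM.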

Compound 3, concentration for 50% growth inhibition: 3600 nM
Estimate against measurement, compound 3: 1.2-fold (0.08 log units) below; the range from low to high includes it.
By their numbers in this assay, from the lowest: compounds 1, 2 and 3 (each within the scatter of the next).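

The 2-methoxyphenyl group carries oxygen where 4-chlorophenyl carries chlorine, yet the result is a 1.2-fold higher number from compound 2 to compound 3 (0.09 log units; within the scatter). Replacing 2,3-dihydro-1,4-benzodioxin-2-yl gives a 1.3-fold higher number from compound 1 to compound 3 (0.11 log units; within the scatter), so three different groups on this saturated chain carbon bound to an amine nitrogen now stay within the scatter of one another. No measurement shown here offers an explanation for this.

Still open, from the compounds shown here alone, is whether a carboxylic acid or a pyridine ring on this carbon would move the number beyond the scatter. A longer chain in the shared core poses the same question.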